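The compounds below may be only part of what the source reports. "The series", "measured", "known", "first", "only" and "open" are said of these compounds alone.

Read-out: a functional assay on A549 cells (Homo sapiens) for cytotoxicity, read by MTT assay, with a stated time of 24 h; on this read-out higher numbers stand for weaker inhibition and lower numbers for stronger inhibition.

Compound 1 `FC(F)(F)C(F)(F)C(F)(F)C(F)(F)C(F)(F)C(F)(F)CCn1cc(COc2ccccc2-c2nc3ccccc3s2)nn1` gives 15100 nM.
Compound 2 `Fc1ccc(-n2cc(COc3ccccc3-c3nc4ccccc4s3)nn2)cc1` gives 23300 nM.

On these two numbers compound 2 and compound 1 lie within the scatter of each other in this assay, so the pair gives no direction to build on. Compound 3 `FC(F)(F)c1cccc(-n2cc(COc3ccccc3-c3nc4ccccc4s3)nn2)c1` carries the change (3-(trifluoromethyl)phenyl in place of 4-fluorophenyl on an aromatic nitrogen). Going by the values given here, no measured step covers a change of this kind, so the expected step is small, with no direction beyond the scatter: a 1.2-fold lower number from compound 2 to compound 3 (0.07 log units; within the scatter). Compound 3 is therefore expected near the number of compound 2, at 20000 nM in this assay, with a range from 7000 nM to 60000 nM.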

Compound 3, half-maximal inhibitory concentration: 11100 nM
The estimate for compound 3 lay 1.8-fold (0.26 log units) above the measured number, within the range that was stated.
By their numbers in this assay, from the lowest: compounds 3, 1 and 2 (each within the scatter of the next, the first and the last beyond it).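

Going by these compounds alone, the change on the aromatic nitrogen, 3-(trifluoromethyl)phenyl in place of 4-fluorophenyl, gives a 2.1-fold lower number from compound 2 to compound 3 (0.32 log units; beyond the scatter) in this assay and is the first step beyond the scatter. This shows that the aryl group at this position can shift the read-out, although only modestly. No data on hand account for the step.

The fluorine-bearing group and its place on the phenyl ring change together, so their contributions cannot be separated. As far as these compounds go, how an amine or a carboxylic acid on that phenyl ring would read remains open.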